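The source may hold more compounds than are shown below. What is called first, only, known or untested is meant among the compounds shown, and "the series" means these compounds.

Measured in an assay on cells for inhibition of Amine oxidase [flavin-containing] B (Homo sapiens), read by fluorescence and Amplex Red, using microsomes, with a stated time of 15 min; a higher number here means a weaker inhibitor, a lower number a stronger inhibitor:
compound 1 `Cc1ccc2oc(=O)c(C(=O)Nc3ccccc3)cc2c1` gives 15.3 nM
compound 2 `Cc1cccc(NC(=O)c2coc3ccc(C)cc3c2=O)c1` gives 17.1 nM
compound 3 `COc1ccc2occ(C(=O)Nc3cccc(C)c3)c(=O)c2c1` gives 21.8 nM

Compound 3 holds the highest of the three numbers in this assay, yet its gap to compound 2 and to compound 1 is within the scatter, so the three stand together. Among the measured compounds shown here, the only single-point step among them, a 1.3-fold higher number from compound 2 to compound 3 (0.11 log units; within the scatter), is likewise within the scatter. Compound 4 `COc1ccc2occ(C(=O)Nc3ccc(Cl)cc3)c(=O)c2c1` has not yet been measured. It differs from compound 3 in one place: 4-chlorophenyl in place of 3-methylphenyl on an amide-type nitrogen. For the measured compounds named here, no measured step touches the group on the amide nitrogen, and compound 1 and compound 2 differ from each other in more than one place, so their two values can only be said to lie close together. One therefore expects compound 4 to show no step beyond the scatter, a 1.0-fold higher number from compound 3 to compound 4 (0.00 log units; within the scatter). Compound 4 is estimated at 22 nM, with a range from 8 nM to 60 nM.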

Compound 4, half-maximal inhibitory concentration: 10.3 nM
Estimate against measurement, compound 4: 2.1-fold (0.33 log units) above, within the range that was stated.
By their numbers in this assay, from the lowest: compounds 4, 1, 2 and 3 (each within the scatter of the next, the first and the last beyond it).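

Among the compounds shown here, the group on the amide nitrogen is the first place where a single change moves the number in this assay beyond the scatter: 4-chlorophenyl in place of 3-methylphenyl gives a 2.1-fold lower number from compound 3 to compound 4 (0.33 log units; beyond the scatter). The one earlier step, methoxy in place of methyl on an aromatic carbon, stayed within the scatter, so this position is the only one shown to respond, if modestly. Nothing available here accounts for the change.

The two groups differ in both substituent and ring position, so 3-chlorophenyl or 4-methylphenyl would be needed to separate these. As far as these compounds go, how a carboxylic acid, an amine or a longer chain would read on the amide nitrogen remains open.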